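The compounds below may be only part of what the source reports. "The series", "measured", "known", "first", "only" and "open" are said of these compounds alone.

Working notes on the series.

Of the compounds shown here, three of this set have been measured in a functional assay on A-375 cells (Homo sapiens) for antiproliferative activity, read by CCK-8 assay, with a stated time of 72 h, tested at 2 uM; a higher number here means a stronger effect of the compound at the concentration tested, a lower number a weaker effect. Compound 1, `Nc1ccccc1NC(=O)c1ccc(CSC(=S)N2CCN(C3CCCCC3)CC2)cc1`, gives 31.7% in this assay. Compound 2, `CC1CCCCN1C(=S)SCc1ccc(C(=O)Nc2ccccc2N)cc1`, gives 42.5% in this assay. Compound 3, `Nc1ccccc1NC(=O)c1ccc(CSC(=S)N2CCc3ccc([N+](=O)[O-])cc32)cc1`, gives 22.1% in this assay. Among these three numbers compound 1 stands second highest: the number of compound 3 lies close to it, within the usual scatter, while the number of compound 2 lies higher by a margin beyond the scatter. No pair of these compounds differs in only one place, so no single step can be read from the measured numbers.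

Compound 4, `Cc1ccc(N2CCN(C(=S)SCc3ccc(C(=O)Nc4ccccc4N)cc3)CC2)cc1`, is not yet measured. It differs from compound 1 as follows: 4-methylphenyl in place of cyclohexyl on an amine nitrogen in a ring. Among the compounds with values here, nothing among the measured compounds shows what such an exchange does in this assay; the nearest comparison is between compounds 1 and 2, which differ in more than one place. The step expected here is small and of no certain direction, an estimated a number 2.3 percentage points higher from compound 1 to compound 4 (within the scatter), within the scatter. For compound 4 in this assay an inhibition of about 34% is expected, with a likely range from 20% to 50%.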

Compound 4, a percentage reported as inhibition, at one concentration (the size of the read-out at that concentration, not a potency): 25.8%
For compound 4 the middle estimate is 8.2 percentage points above the measured one, within the range that was stated.
By their numbers in this assay, from the lowest: compounds 3, 4 and 1 (each within the scatter of the next); then compound 2.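

Within the data shown here, this exchange is the first single-place step, and it falls on the amine nitrogen in the six-membered non-aromatic ring with 2 nitrogen. In this assay, 4-methylphenyl in place of cyclohexyl at this position gives a number 5.9 percentage points lower from compound 1 to compound 4 (within the scatter), so the assay does not separate the aromatic ring from the non-aromatic one here. No measured property in hand bears on this result.

The compounds shown leave open whether unsubstituted phenyl, or 4-methylphenyl with the methyl replaced by a carboxylic acid, would behave in the same way on this nitrogen. Going by these compounds, it also remains open whether a longer chain such as n-hexyl, or a benzyl group, at the same place would give a step beyond the scatter.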